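The source may hold more compounds than are shown below. What is called first, only, known or untested is meant among the compounds shown, and "the series" means these compounds.

In an ADME assay on MCF-10A cells (Homo sapiens) for cytotoxicity, read by sulforhodamine B assay, with a stated time of 48 h (a lower number here means a stronger inhibitor of growth, a higher number a weaker inhibitor of growth), compound 3 `Cc1ccc2nc(/N=C3\C(=O)N(CN(C)C)c4ccccc43)sc2c1` gives 13400 nM. Compound 1 `Cc1ccc2nc(/N=C3\C(=O)N(CN4CCCCC4)c4ccccc43)sc2c1` carries piperidin-1-yl in place of dimethylamino on a saturated chain carbon bound to an amide-type nitrogen in a ring, and in this assay compound 1 gives 38900 nM, which is a 2.9-fold higher number from compound 3 to compound 1 (0.46 log units; beyond the scatter). Compound 2 `Cc1ccc2nc(/N=C3\C(=O)N(CN(C)C)c4cccc(Br)c43)sc2c1` differs from compound 3 by bromo in place of hydrogen on an aromatic carbon; in this assay compound 2 gives 21800 nM, and the step is a 1.6-fold lower number from compound 2 to compound 3 (0.21 log units; within the scatter). Compound 4 `Cc1ccc2nc(/N=C3\C(=O)N(CN4CCCCC4)c4cccc(Br)c43)sc2c1` has not yet been measured. Going by the values given here, it differs from compound 2 by piperidin-1-yl in place of dimethylamino on a saturated chain carbon bound to an amide-type nitrogen in a ring, the same change at the same place as the one measured earlier, and only that single earlier pair shows it. Because the measured step of a 2.9-fold higher number from compound 3 to compound 1 (0.46 log units; beyond the scatter) points one way, compound 4 is expected to show the step of a 2.9-fold higher number from compound 2 to compound 4 (0.46 log units; beyond the scatter). The estimate for compound 4 is 63000 nM, expected between 30000 nM and 130000 nM.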

Compound 4, concentration for 50% growth inhibition: 18400 nM
Compound 4: middle estimate off by 3.4-fold (0.53 log units), on the high side; measured number below the stated range.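

Replacing dimethylamino with piperidin-1-yl does not carry over unchanged from the core without bromo to the core with it: the same change on two cores in this assay, a 2.9-fold higher number (0.46 log units; beyond the scatter) from compound 3 to compound 1 and a 1.2-fold lower number (0.07 log units; within the scatter) from compound 2 to compound 4, 3.4-fold (0.54 log units) apart, beyond the scatter of two such steps. On the bromo core, that replacement gives a 1.2-fold lower number from compound 2 to compound 4 (0.07 log units; within the scatter), while adding bromo to the piperidin-1-yl compound gives a 2.1-fold lower number from compound 1 to compound 4 (0.33 log units; beyond the scatter), and the bromo change also differs between the two amines: the same change on two cores in this assay, a 1.6-fold lower number (0.21 log units; within the scatter) from compound 2 to compound 3 and a 2.1-fold higher number (0.33 log units; beyond the scatter) from compound 4 to compound 1, 3.4-fold (0.54 log units) apart, beyond the scatter of two such steps. In these four compounds, the size of each step therefore depends on the group at the other place, but one pair per core cannot show why this happens or predict the result on other cores.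

The compounds shown leave open whether another ring amine, such as morpholin-4-yl or pyrrolidin-1-yl, would behave like piperidin-1-yl on both cores. They also leave open whether chloro in place of bromo would give the same steps.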